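Demethylation on the Ring Nitrogen: Second Instance in the Series

The compounds below may be only part of what the source reports. "The series", "measured", "known", "first", "only" and "open" are said of these compounds alone.

Of the compounds shown here, three have been measured in a functional assay on A549 cells (Homo sapiens) for inhibition, read by MTT assay, with a stated time of 72 h, tested at 20 uM (on this read-out lower numbers stand for less inhibition and higher numbers for more inhibition at the one concentration tested (going by the name of the read-out)), so far. Compound 1 `c1cc(N2CCCCC2)nc(Nc2ccc(Oc3ncnc4sccc34)cc2)n1` gives 64.8% in this assay. Compound 3 `CN(c1ccc(Oc2ncnc3sccc23)cc1)c1nccc(N2CCCCC2)n1` gives 51.9% in this assay. Compound 2 `CN(c1ccc(Oc2ncnc3ccsc23)cc1)c1nccc(N2CCc3ccccc3C2)n1` gives 69.9% in this assay.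

Compound 3 and compound 1 differ in one place, (hydrogen in place of methyl on a nitrogen on an aromatic ring), and this change produced a number 12.9 percentage points higher from compound 3 to compound 1 (beyond the scatter). Compound 2 and compound 3 differ in more than one place; the difference between the two cores is not broken down here, and their values simply show that the number for compound 2 is beyond the scatter from that of compound 3. The values of compound 2 and compound 1 lie within the scatter of each other, so no order is read into them.

Compound 4 `c1ccc2c(c1)CCN(c1ccnc(Nc3ccc(Oc4ncnc5ccsc45)cc3)n1)C2` is not yet measured. It differs from compound 2 by hydrogen in place of methyl on a nitrogen on an aromatic ring, the same change as that from compound 3 to compound 1, with the same place as described for that earlier pair. If the change acts on compound 2 as it did from compound 3 to compound 1, an upward step is expected; with only one earlier instance, the expectation is held loosely. The step from compound 2 to compound 4 is estimated at a number 10.1 percentage points higher from compound 2 to compound 4 (beyond the scatter) in this assay, resting on the measured step from compound 3 to compound 1 of a number 12.9 percentage points higher from compound 3 to compound 1 (beyond the scatter). For compound 4 the estimate in this assay is 80%, expected to lie between 68% and 92%.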

Compound 4, a percentage reported as inhibition, at one concentration (the size of the read-out at that concentration, not a potency): 54.9%
For compound 4 the middle estimate is 25.1 percentage points above the measured one; measured number outside the range, below it.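

In this assay, hydrogen in place of methyl on a nitrogen on an aromatic ring gives a number 15 percentage points lower from compound 2 to compound 4 (beyond the scatter), so the change does not keep its direction from one core to the other. The two steps with this same change point in opposite directions, and the gap between them is not scatter: the same change on two cores in this assay, a number 12.9 percentage points higher (beyond the scatter) from compound 3 to compound 1 and a number 15 percentage points lower (beyond the scatter) from compound 2 to compound 4, 27.9 percentage points apart, beyond the scatter of two such steps. This shows that, for these two pairs, a step measured on the core of compound 1 cannot be carried over to the core of compound 4, even as a matter of sign; it does not show which feature of the cores goes with the reversal, what causes it, or how the change would behave on any further core, and each step is a read-out at one concentration rather than a difference in potency.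

The compounds shown leave open which of the differences between the two cores goes with the reversal, as no pair here varies one of those differences alone. They also leave open how either core responds to a group other than hydrogen or methyl on that nitrogen, such as ethyl or a longer chain.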